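This account rests on a few compounds, and the source may have more. Where it says the series, first, only, none or still open, it means among the compounds named here.

Compound 1 `NS(=O)(=O)c1ccc(N2C(=O)CC(C3CCCCC3=O)C2=O)cc1` was examined in an assay on cells (1-87 tumor cell line) for inhibition of Polyunsaturated fatty acid 5-lipoxygenase (Homo sapiens), with a stated time of 5 min (a lower number here means a stronger inhibitor, a higher number a weaker inhibitor), where compound 1 gives 21300 nM. That is the highest of the two numbers recorded in this assay. Among the measured compounds shown here, the only other measured compound, compound 2 `COc1ccc(C(=O)CC2CC(=O)N(c3ccc(S(N)(=O)=O)cc3)C2=O)cc1`, gives 4740 nM in this assay, a lower number that lies beyond the usual scatter; the two structures differ in more than one place, so no single step between them is defined.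

Compound 3 `O=C1CCCCC1C1CC(=O)N(c2ccccc2)C1=O` has not been measured. It differs from compound 1 in one place: hydrogen in place of sulfamoyl on an aromatic carbon, para to a large group. For the measured compounds named here, no measured pair shows the effect of this particular change, so the size of the step from compound 1 to compound 3 in this assay cannot be read from the data. Compound 3 is therefore expected to sit close to compound 1, with a step of a 1.2-fold higher number from compound 1 to compound 3 (0.07 log units; within the scatter) that may well fall within the scatter. The value of compound 3 in this assay is estimated at 25000 nM, with a plausible range from 6000 nM to 100000 nM.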

Compound 3, half-maximal inhibitory concentration: 78300 nM
Compound 3: middle estimate off by 3.1-fold (0.50 log units), on the low side, within the range that was stated.
By their numbers in this assay, from the lowest: compound 2; then compound 1; then compound 3.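

Replacing sulfamoyl with hydrogen on the aromatic carbon para to a large group gives a 3.7-fold higher number from compound 1 to compound 3 (0.57 log units; beyond the scatter) in this assay. Among the compounds shown here, this is the first single change that can be read, and it shows that, on the core of compound 1, the position is not indifferent to this change: the compound carrying sulfamoyl has the lower number, and so is the stronger inhibitor of this pair. No measurement given here explains the size or direction of this step.

The compounds shown leave open whether sulfamoyl itself is needed at this position, or whether a carboxylic acid, a methylsulfonyl group or an amine placed there would give a similar number. For the compounds shown here, they also leave open whether the same step would appear with the side chain of compound 2 in place of the one on compound 1.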